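The source may report more compounds than this note shows. Statements on the series, on what has been measured and on what is new or still open speak of the compounds shown alone.

Measured compounds:
compound 1 `O=C(CCCCC1CCSS1)NCc1cn(CCCOc2ccc3cc(-c4ccc(Br)cc4)c(=O)oc3c2)nn1` gives 39.5%
compound 2 `O=C(CCCCC1CCSS1)NCc1cn(CCCCOc2ccc3ccc(=O)oc3c2)nn1` gives 40.5%

Going by the values given here, in a functional assay on PC-12 cells (Rattus norvegicus) for cytotoxicity, read by MTT assay, with stated times of 3 h and 2 h, tested at 0.1 uM (on this read-out lower numbers stand for a weaker effect and higher numbers for a stronger effect at the one concentration tested), compound 2 gives 40.5% and compound 1 gives 39.5%; the two numbers lie within the scatter of each other, and since the two structures differ in more than one place no single step connects them. Compound 3 `O=C(CCCCC1CCSS1)NCc1cn(CCCCOc2ccc3cc(-c4ccc(Cl)c(Cl)c4)c(=O)oc3c2)nn1` has not yet been measured. It differs from compound 2 by 3,4-dichlorophenyl in place of hydrogen on an aromatic carbon. Among the compounds with values here, no measured step of this kind is known, so in this assay no move beyond the scatter is expected. Compound 3 is expected to give 41%, with a range from 30% to 52%. The expected step of a number 0.5 percentage points higher from compound 2 to compound 3 (within the scatter) is estimated to sit within the scatter.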

Compound 3, a percentage reported as activity, at one concentration (the size of the read-out at that concentration, not a potency): 39.6%
Estimate against measurement, compound 3: 1.4 percentage points above, and the stated range covers the measured number.
By their numbers in this assay, from the lowest: compounds 1, 3 and 2 (each within the scatter of the next).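

In this assay, 3,4-dichlorophenyl in place of hydrogen on this aromatic carbon gives a number 0.9 percentage points lower from compound 2 to compound 3 (within the scatter). At the one concentration tested, adding this aromatic ring at a site two atoms from the ring oxygen therefore leaves the read-out within the scatter. Nothing available here bears on why this is so.

Going by these compounds, whether an amine or a carboxylic acid on this carbon would move the read-out beyond the scatter remains open. The shown compounds also leave open how an unsubstituted phenyl would compare with the 3,4-dichlorophenyl.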